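Removing the methyl from compound 3

The source may report more compounds than this note shows. Statements on the series, on what has been measured and on what is new or still open speak of the compounds shown alone.

Three compounds of the shared core have numbers in an assay for binding affinity to Neuronal acetylcholine receptor; alpha4/beta2 (Rattus norvegicus); a lower number here means a stronger inhibitor, a higher number a weaker inhibitor. Compound 1 `COc1ccc(-c2cnc3cc4c(cc3n2)C2CNCC4C2)cc1` gives 26 nM. Compound 2 `Fc1cc2c(cc1F)C1CNCC2C1` gives 0.28 nM. Compound 3 `Cc1ccc2cc3c(cc2n1)C1CNCC3C1` gives 0.76 nM. On these numbers compound 3 stands second highest of the three: its nearest neighbour is compound 2, with the lower number, and that gap lies beyond the scatter; compound 1 lies furthest away, with the higher number, also beyond the scatter.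

Compound 4 `c1cnc2cc3c(cc2c1)C1CNCC3C1` is not yet measured. Compared with compound 3 the change is hydrogen in place of methyl on an aromatic carbon. For the measured compounds named here, no step between two measured compounds matches this change, so the expectation rests on the size of the change alone. Given how small the change is, the step of a 1.4-fold higher number from compound 3 to compound 4 (0.16 log units; within the scatter) is expected to be a slight rise in the number, at or near the edge of the scatter. Compound 4 is expected at 1.1 nM, with a range from 0.35 nM to 3.5 nM.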

Compound 4, inhibition constant: 1.6 nM
Estimate against measurement, compound 4: 1.5-fold (0.16 log units) below, within the range that was stated.
By their numbers in this assay, from the lowest: compound 2; then compound 3; then compound 4; then compound 1.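

In this assay, hydrogen in place of methyl on an aromatic carbon next to the ring nitrogen gives a 2.1-fold higher number from compound 3 to compound 4 (0.32 log units; beyond the scatter), a modest step and the first in this series that isolates a single place. The methyl therefore goes with the lower number, yet its loss costs little, and compound 4 still reads 1.6 nM with only a hydrogen at this position. No independent measurement on these compounds bears on why the number moves with this change.

On these data alone, whether a larger group here, such as ethyl, methoxy or an amine, would lower the number further or raise it remains open, since one step gives only one direction. Equally open, as far as these compounds go, is whether a methyl or chlorine elsewhere on this ring would produce a step of similar size.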